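Sulfone series: switching the aryl group on the alkene

A few compounds are considered here, and "the series" means these few. Any claim that something is new, unique, unknown or untested is made for them only; others in the source may bear on it.

Compound 1 `COc1ccc(/C=C(\C(=O)c2ccc(Br)cc2)S(=O)(=O)c2ccc(Br)cc2)cc1` is the reference for this note. In a functional assay on DU-145 cells (Homo sapiens) for inhibition, read by trypan blue exclusion, with a stated time of 96 h (on this read-out lower numbers stand for stronger inhibition of growth and higher numbers for weaker inhibition of growth), compound 1 gives 25000 nM. Two analogues change only the group on the sulfonyl sulfur: compound 2 `COc1ccc(/C=C(\C(=O)c2ccc(Br)cc2)S(=O)(=O)Cc2ccc(Cl)cc2)cc1` gives 25000 nM in this assay, and compound 3 `COc1ccc(/C=C(\C(=O)c2ccc(Br)cc2)S(=O)(=O)Cc2ccc(F)cc2)cc1` gives 25000 nM. The step of no change at the digits printed from compound 1 to compound 2 (within the scatter) and the step of no change at the digits printed from compound 1 to compound 3 (within the scatter) leave the read-out unmoved, as does no change at the digits printed from compound 2 to compound 3 (within the scatter). Compound 1 therefore stands level with compounds 2 and 3 in this assay, and the three numbers describe one flat set.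

Compound 4 `Nc1c(Br)cc(Br)cc1/C=C(\C(=O)c1ccc(Br)cc1)S(=O)(=O)c1ccc(Br)cc1` is not yet measured. It differs from compound 1 at the alkene, not at the sulfonyl sulfur: 2-amino-3,5-dibromophenyl in place of 4-methoxyphenyl on a double-bonded chain carbon bound to a double-bonded chain carbon. Among the measured compounds shown here, none of the measured steps touches this position, and the three that exist all show no change beyond the scatter, so they give no information on the direction a change at the alkene might take. For the measured compounds named here, with no step bearing on the new group, the expectation for compound 4 rests on the flat numbers of compounds 1 to 3 alone.

The expected step of no change at the digits printed from compound 1 to compound 4 (within the scatter) is therefore none beyond the scatter. On these data alone, compound 4 is estimated at 25000 nM in this assay, with a range from 6000 nM to 50000 nM, the range being wide on the low side because the new group is untested in this set.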

Compound 4, concentration for 50% growth inhibition: 25000 nM
Compound 4: the middle estimate sits on the measured number at the digits printed; the measured number falls inside the stated range.
By their numbers in this assay, from the lowest: compounds 1, 2, 3 and 4 (each within the scatter of the next).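

In this assay, among the compounds shown here, the group on the alkene now has a reading of its own, whereas all the earlier steps changed only the group on the sulfonyl sulfur: replacing 4-methoxyphenyl with 2-amino-3,5-dibromophenyl gives no change at the digits printed from compound 1 to compound 4 (within the scatter) in this series. The flat picture therefore extends to a second place on the shared core, even though the entering group brings nitrogen and bromine, loses the oxygen of the leaving group, and has 1 hydrogen-bond donor where the leaving group has 0. Nothing available explains why the read-out stays level across this exchange.

Open, on these data alone, is whether a carboxylic acid or a longer chain on the aryl group at this carbon would leave the read-out level in this assay, or whether a pair of changes would move it, such as 2-amino-3,5-dibromophenyl on the alkene combined with 4-fluorobenzyl on the sulfonyl sulfur. Also open, as far as these compounds go, is what happens when the 4-bromophenyl on the carbonyl gives way to another group, such as a pyridine, as that part of the core stays the same in all four compounds.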